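Dimethylamino for Piperidinyl on Two Related Cores

A few compounds are considered here, and "the series" means these few. Any claim that something is new, unique, unknown or untested is made for them only; others in the source may bear on it.

Compound 1 `O=S(=O)(c1ccccc1)n1ccc2c(N3CCCCC3)cccc21` and compound 2 `CN(C)c1cccc2c1ccn2S(=O)(=O)c1ccccc1` share one core and differ in a single place: dimethylamino in place of piperidin-1-yl on an aromatic carbon. In an assay on isolated protein for displacement of a labelled ligand from 5-hydroxytryptamine receptor 6 (Homo sapiens), read by scintillation counting, with a stated time of 1 h (on this read-out higher numbers stand for weaker inhibition and lower numbers for stronger inhibition), compound 1 gives 128 nM, and compound 2 gives 65 nM, a step of a 2.0-fold lower number from compound 1 to compound 2 (0.29 log units; within the scatter). Compound 3 `O=S(=O)(c1ccccc1)n1ccc2cc(N3CCCCC3)ccc21` is built from the same atoms as compound 1, joined differently; the difference between the two cores is not broken down here. In this assay compound 3 gives 360 nM, the highest of the three numbers. Compound 4 `CN(C)c1ccc2c(ccn2S(=O)(=O)c2ccccc2)c1` is not yet measured and differs from compound 3 by dimethylamino in place of piperidin-1-yl on an aromatic carbon. This is the same kind of change as that from compound 1 to compound 2, though the place now sits meta to a fused ring and para to a fused ring rather than ortho to a fused ring and meta to a fused ring. Because the earlier step was a 2.0-fold lower number from compound 1 to compound 2 (0.29 log units; within the scatter), compound 4 is expected to show a step of about a 2.0-fold lower number from compound 3 to compound 4 (0.30 log units; within the scatter). The estimated value for compound 4 in this assay is 180 nM.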

Compound 4, inhibition constant: 82 nM
Compound 4: the middle estimate sits 2.2-fold (0.34 log units) above what was measured, and the stated range ends above it.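

On the core of compound 3, dimethylamino in place of piperidin-1-yl gives a 4.4-fold lower number from compound 3 to compound 4 (0.64 log units; beyond the scatter) in this assay. Set beside the same change on the core of compound 1, the two steps cannot be told apart in size: the same change on two cores in this assay, a 2.0-fold lower number (0.29 log units; within the scatter) from compound 1 to compound 2 and a 4.4-fold lower number (0.64 log units; beyond the scatter) from compound 3 to compound 4, 2.2-fold (0.35 log units) apart, within the scatter of two such steps. This supports carrying the change across these two cores, but it rests on two pairs only and does not show that the step would hold on any other core in the series.

The compounds shown leave open how a primary amine or a pyrrolidin-1-yl group would read on the same aromatic carbon. They also leave open whether a morpholin-4-yl group would give a step of similar size on either core.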